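The source may hold more compounds than are shown below. What is called first, only, known or untested is meant among the compounds shown, and "the series" means these compounds.

Measured compounds in an assay on CHO cells for displacement of a labelled ligand from adenosine receptor A3 (Homo sapiens), read by scintillation counting, with a stated time of 120 min, tested at 10 uM; on this read-out lower numbers stand for less inhibition and higher numbers for more inhibition at the one concentration tested (going by the name of the read-out):
compound 1 `COc1ccc(N2CCN(Cc3csc(N)c3C(=O)c3ccc(Cl)cc3)CC2)cc1` gives 0%
compound 2 `Nc1scc(CN2CCN(c3ccc([N+](=O)[O-])cc3)CC2)c1C(=O)c1ccc(Cl)cc1` gives 2%

Among the measured compounds shown here, compound 1 stands lowest of the two numbers, with compound 2 nearest; the single step between them, a number 2 percentage points higher from compound 1 to compound 2 (within the scatter), lies within the scatter, so the two numbers show no order. Both compounds sit at the bottom of the read-out, with essentially no inhibition at the one concentration tested.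

Compound 3 `Nc1scc(CN2CCN(c3cc(F)ccc3F)CC2)c1C(=O)c1ccc(Cl)cc1` has not yet been measured. It differs from compound 1 in one place: 2,5-difluorophenyl in place of 4-methoxyphenyl on an amine nitrogen in a ring. The change falls on the group on an amine nitrogen in a ring, the same group that is altered between compound 1 and compound 2, and that step, a number 2 percentage points higher from compound 1 to compound 2 (within the scatter), stayed within the scatter. For the measured compounds named here, no other measured step bears on this change, and the two numbers at hand give no sign of a shift beyond the scatter. The expectation for a number 3 percentage points higher from compound 1 to compound 3 (within the scatter) is therefore no step beyond the scatter, in no preferred direction. Compound 3 is estimated at 3% in this assay, with a range from -8% to 15%.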

Compound 3, a percentage reported as inhibition, at one concentration (the size of the read-out at that concentration, not a potency): 2%
The estimate for compound 3 lay 1 percentage points above the measured number; the measured number falls inside the stated range.
By their numbers in this assay, from the lowest: compounds 1, 2 and 3 (each within the scatter of the next).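

Working from this assay, the swap on the amine nitrogen in a ring to 2,5-difluorophenyl gives a number 2 percentage points higher from compound 1 to compound 3 (within the scatter) and gives no change at the digits printed from compound 2 to compound 3 (within the scatter) as well. This extends the flat picture from two aryl groups to three, and the new group brings two fluorine atoms and 0 hydrogen-bond acceptors where 4-methoxyphenyl has 1, with no step beyond the scatter. Across compounds 1, 2 and 3, then, exchanging one substituted phenyl group for another at this position leaves the number at the bottom of the read-out, and no measurement here bears on why.

Going by these compounds, all three compounds carry a phenyl group on that ring nitrogen, so the effect of a non-aromatic group there, such as a longer alkyl chain or one ending in a carboxylic acid or an amine, remains open. Among the compounds shown here, also open is whether changes elsewhere on the shared core, such as a methoxy group or a hydrogen in place of the chlorine, would move the number at all, since every step so far falls at this one position.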